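Swapping the hydrazone aryl arm for a chloro-fluoro phenyl

The source may hold more compounds than are shown below. What is called first, only, known or untested is meant among the compounds shown, and "the series" means these compounds.

Compound 3 `COc1ccc(/C=N/NC(=O)Nc2ccc(Oc3ccnc(-c4nncn4CCN(C)C)c3)c(F)c2)cc1O` gives the lowest number of the three in a functional assay on NCI-H460 cells (Homo sapiens) for cytotoxicity, read by MTT assay, with a stated time of 72 h (on this read-out lower numbers stand for stronger inhibition and higher numbers for weaker inhibition), namely 620 nM. Compound 1 `COc1ccc(/C=N/NC(=O)Nc2ccc(Oc3ccnc(-c4nncn4CCN(C)C)c3)c(F)c2)c(OC)c1` gives 1570 nM in this assay, and compound 2 `CN(C)CCn1cnnc1-c1cc(Oc2ccc(NC(=O)N/N=C/c3ccc(O)c(F)c3)cc2F)ccn1` gives 2620 nM. Compound 4 `CN(C)CCn1cnnc1-c1cc(Oc2ccc(NC(=O)N/N=C/c3ccc(F)cc3Cl)cc2F)ccn1` differs from compound 3 in one place: 2-chloro-4-fluorophenyl in place of 3-hydroxy-4-methoxyphenyl on a carbon with a double bond to nitrogen. The measured steps that bear on this all exchange the same aryl group: a 2.5-fold lower number from compound 1 to compound 3 (0.40 log units; beyond the scatter), a 4.2-fold lower number from compound 2 to compound 3 (0.63 log units; beyond the scatter) and a 1.7-fold higher number from compound 1 to compound 2 (0.22 log units; within the scatter). For the measured compounds named here, both measured departures from the 3-hydroxy-4-methoxyphenyl arm gave modestly higher numbers, so a rise of similar size is expected for compound 4, although no measured compound carries a ring of this kind at that place. Compound 4 is therefore estimated at 1500 nM (range 500 nM to 5000 nM). This is expected to be a step of a 2.4-fold higher number from compound 3 to compound 4 (0.38 log units; beyond the scatter).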

Compound 4, half-maximal inhibitory concentration: 720 nM
Compound 4: the middle estimate sits 2.1-fold (0.32 log units) above what was measured; the measured number falls inside the stated range.
By their numbers in this assay, from the lowest: compounds 3 and 4 (each within the scatter of the next); then compounds 1 and 2 (each within the scatter of the next).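

In this assay, the 2-chloro-4-fluorophenyl arm, with 0 hydrogen-bond donors and 0 hydrogen-bond acceptors, matches the 3-hydroxy-4-methoxyphenyl arm, with a 1.2-fold higher number from compound 3 to compound 4 (0.06 log units; within the scatter) and thus no real change. Against the other two arms, the same exchange gives a 3.6-fold lower number from compound 2 to compound 4 (0.56 log units; beyond the scatter) and a 2.2-fold lower number from compound 1 to compound 4 (0.34 log units; beyond the scatter), so the lower numbers at this place do not need a hydroxyl, and compound 2 shows that a hydroxyl does not ensure them. Nothing available explains this result.

As far as these compounds go, whether the chlorine or the fluorine matters more remains open. So does the effect of a ring bearing an amine or a carboxylic acid on that carbon.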